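The source may hold more compounds than are shown below. What is called first, only, known or untested is meant among the compounds shown, and "the series" means these compounds.

Compound 1 `CCC(CC)NC(=O)c1cccc2[nH]c(-c3ccc(OC)c(OC)c3)nc12` and compound 3 `CCC(CC)NC(=O)c1cccc2[nH]c(-c3ccc(OC)c(OC)c3OC)nc12` share a core and differ only by methoxy in place of hydrogen on an aromatic carbon. In an ADME assay on Vero cells (Chlorocebus sabaeus) for cytotoxicity (a higher number here means that more compound is tolerated, a lower number that less compound is tolerated), compound 1 gives 2.23 uM, while compound 3 gives 32.3 uM, a change of a 14-fold higher number from compound 1 to compound 3 (1.16 log units; beyond the scatter). Compound 2 `COc1ccc(-c2nc3c(C(=O)Nc4cnc(Cl)cn4)cccc3[nH]2)cc1OC` arises from compound 1 by 5-chloropyrazin-2-yl in place of pentan-3-yl on an amide-type nitrogen, and in this assay compound 2 gives 78.3 uM, a change of a 35-fold higher number from compound 1 to compound 2 (1.55 log units; beyond the scatter). Compound 4 `COc1ccc(-c2nc3c(C(=O)Nc4cnc(Cl)cn4)cccc3[nH]2)c(OC)c1OC` is not yet measured; it differs from compound 3 by 5-chloropyrazin-2-yl in place of pentan-3-yl on an amide-type nitrogen, at a place described in the same words as for compound 1 and compound 2, so it is the same change. For compound 3 to compound 4 a step of a 4.6-fold higher number from compound 3 to compound 4 (0.67 log units; beyond the scatter) is expected in this assay, somewhat smaller than the earlier one because compound 3 already starts at 32.3 uM. Compound 4 is therefore estimated at 150 uM, between 50 uM and 600 uM.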

Compound 4, half-maximal toxic concentration: 65.2 uM
Compound 4: the middle estimate sits 2.3-fold (0.36 log units) above what was measured; low and high end bracket the measured number.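

In this assay, 5-chloropyrazin-2-yl in place of pentan-3-yl still gives a higher number on the core of compound 3 (a 2.0-fold higher number from compound 3 to compound 4 (0.31 log units; beyond the scatter)), but the size of the step does not carry over from the core of compound 1: the same change on two cores in this assay, a 35-fold higher number (1.55 log units; beyond the scatter) from compound 1 to compound 2 and a 2.0-fold higher number (0.31 log units; beyond the scatter) from compound 3 to compound 4, 17-fold (1.24 log units) apart, beyond the scatter of two such steps

The added methoxy also depends on its surroundings, since with the 5-chloropyrazin-2-yl amide its step (a 1.2-fold lower number from compound 2 to compound 4 (0.08 log units; within the scatter)) stays within the scatter, unlike its step with the pentan-3-yl amide: the same change on two cores in this assay, a 14-fold higher number (1.16 log units; beyond the scatter) from compound 1 to compound 3 and a 1.2-fold lower number (0.08 log units; within the scatter) from compound 2 to compound 4, 17-fold (1.24 log units) apart, beyond the scatter of two such steps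

So the two changes do not simply add up here, and these four compounds show neither why that is nor whether it would hold on other cores.

Still open, on these data alone, is how a phenyl ring or a shorter chain such as ethyl on the amide-type nitrogen would behave, with and without the added methoxy.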